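Chloro for fluoro on a shared dienone core, cytotoxicity

The source may hold more compounds than are shown below. What is called first, only, known or untested is meant among the compounds shown, and "the series" means these compounds.

Compound 1 `O=C1/C(=C/c2ccc(F)cc2)CCC/C1=C\c1ccccc1[N+](=O)[O-]`: 2200 nM
Compound 2 `O=C1/C(=C/c2ccc(Cl)cc2)CCC/C1=C\c1ccccc1[N+](=O)[O-]`: 6100 nM
Compound 3 `O=C1/C(=C/c2ccc(F)cc2)CCC/C1=C\c1ccc([N+](=O)[O-])cc1`: 15000 nM

All three were tested in a functional assay on HSC-4 cells (Homo sapiens) for cytotoxicity, with a stated time of 24 h; a higher number here means that more compound is tolerated, a lower number that less compound is tolerated. Compound 1 and compound 2 share a core and differ in one place: chloro in place of fluoro on an aromatic carbon. That change gave a 2.8-fold higher number from compound 1 to compound 2 (0.44 log units; beyond the scatter).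

Compound 3 carries the same atoms as compound 1, joined differently; the difference between the two cores is not broken down here. In this assay compound 3 gives the highest of the three numbers, standing a modest distance from compound 2 and further from compound 1.

Compound 4 `O=C1/C(=C/c2ccc(Cl)cc2)CCC/C1=C\c1ccc([N+](=O)[O-])cc1` has not yet been measured in this assay. It stands to compound 3 as compound 2 stands to compound 1: chloro in place of fluoro on an aromatic carbon. The place description is the same word for word as that for the change from compound 1 to compound 2, so this is the same change applied to the other core.

Among the compounds with values here, for compound 4 the expected step is a 2.3-fold higher number from compound 3 to compound 4 (0.37 log units; beyond the scatter), set beside the earlier step because a 2.8-fold higher number from compound 1 to compound 2 (0.44 log units; beyond the scatter) is the only measured instance of this change and nothing here says the second core responds differently. On that basis compound 4 is estimated at 35000 nM, with a range from 15000 nM to 80000 nM to allow for the scatter of such measurements and for the chance that the second core does not follow the first.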

Compound 4, half-maximal cytotoxic concentration: 2700 nM
The estimate for compound 4 lay 13-fold (1.11 log units) above the measured number, and the stated range ends above it.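

In this assay the same exchange of 4-fluorophenyl for 4-chlorophenyl, now made on the second core, gave a 5.6-fold lower number from compound 3 to compound 4 (0.74 log units; beyond the scatter) and so ran opposite to the earlier step. Set side by side, the two steps differ in direction and in size: the same change on two cores in this assay, a 2.8-fold higher number (0.44 log units; beyond the scatter) from compound 1 to compound 2 and a 5.6-fold lower number (0.74 log units; beyond the scatter) from compound 3 to compound 4, 15-fold (1.19 log units) apart, beyond the scatter of two such steps. This shows that, among these four compounds, the step measured on one core could not be carried to the other, so the outcome of this exchange depends on the core that bears it, but it does not show what in the two cores produces the difference, and two pairs cannot tell which of the two steps would be the more typical on any further core.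

The compounds shown leave open whether the reversal extends to other groups in the same place, such as bromo, methyl or methoxy, and whether it persists when the nitro group on the other aromatic ring gives way to an amine or a carboxylic acid. They also leave open whether the nitro group's position alone separates the two cores' responses, or whether a third placement or a different ring size in the core would follow either pair.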